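Methyl on the free hydroxy of compound 2

This account rests on a few compounds, and the source may have more. Where it says the series, first, only, none or still open, it means among the compounds named here.

In a functional assay on MDA-MB-231 cells (Homo sapiens) for antiproliferative activity, read by MTT assay, with a stated time of 72 h (on this read-out lower numbers stand for stronger inhibition and higher numbers for weaker inhibition), compound 1 `COc1cc(/C=C/C(=O)/C=C(O)/C=C/c2ccc(OC(=O)C(C)(CO)CO)c(OC)c2)ccc1OC(=O)C(C)(CO)CO` gives 2670 nM while compound 2 `COc1cc(/C=C/C(O)=C/C(=O)/C=C/c2ccc(OC(=O)C(C)(CO)CO)c(OC)c2)ccc1O` gives 5940 nM as the higher of the two numbers. Compound 3 `COc1ccc(/C=C/C(O)=C/C(=O)/C=C/c2ccc(OC(=O)C(C)(CO)CO)c(OC)c2)cc1OC` differs from compound 2 by methyl in place of hydrogen on an oxygen on an aromatic ring and so turns hydroxy to methoxy. Going by the values given here, the one measured step at such an oxygen is a 2.2-fold higher number from compound 1 to compound 2 (0.35 log units; beyond the scatter) and it is modest, though it concerns a different group. In this assay a similarly modest move to a lower number is therefore expected (a 1.5-fold lower number from compound 2 to compound 3 (0.17 log units; within the scatter)) with little certainty about its direction. For compound 3 the estimated value is 4000 nM with an expected range from 1800 nM to 8500 nM as its limits.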

Compound 3, half-maximal inhibitory concentration: 2550 nM
Compound 3: the middle estimate sits 1.6-fold (0.20 log units) above what was measured; measured number inside the range.
By their numbers in this assay, from the lowest: compounds 3 and 1 (each within the scatter of the next); then compound 2.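

In this assay, methyl on the free hydroxy gives a 2.3-fold lower number from compound 2 to compound 3 (0.37 log units; beyond the scatter) and thus shows that a hydrogen on this oxygen is not needed for the lower number. Methyl and the (1,1-bis(hydroxymethyl)ethyl)carbonyl group on this oxygen cannot be told apart, with a 1.0-fold lower number from compound 1 to compound 3 (0.02 log units; within the scatter) inside the usual scatter, so the larger ester group is not needed either. Nothing available explains these steps.

As far as these compounds go, how an ethyl group or a longer chain ending in an amine or a carboxylic acid would read on this oxygen remains open.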